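This account rests on a few compounds, and the source may have more. Where it says the series, first, only, none or still open, it means among the compounds named here.

Measured compounds in the series:
- compound 1, `COc1nc(C2CCOCC2)ccc1[C@@H](c1ccccc1)[C@@](O)(CCN(C)C)c1cccc2ccccc12`: in a toxicity assay on Vero cells (Chlorocebus sabaeus) for cytotoxicity (on this read-out higher numbers stand for lower toxicity in this test and lower numbers for higher toxicity in this test), compound 1 gives > 50 ug/mL, a limit of the assay rather than a number.
- compound 2, `COc1nc(-c2ccc(C#N)cc2)ccc1[C@@H](c1ccccc1)[C@@](O)(CCN(C)C)c1cccc2ccccc12`: compound 2 gives > 50 ug/mL, again a limit.
- compound 3, `COc1ncc(-c2ccccc2)cc1[C@@H](c1ccccc1)[C@@](O)(CCN(C)C)c1ccccc1`: compound 3 gives > 50 ug/mL, again a limit.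

Compound 2 thus stands at the limit of > 50 ug/mL in this assay, at which 3 of the 3 values shown sit; nothing more than the limit is known for it, and the same holds for the two other values shown. For the measured compounds named here, the single measured step that changes one place, a step that the two limits leave unreadable from compound 1 to compound 2, stays unreadable for that reason. The next compound, compound 4 `COc1nc(-c2cccc(Cl)c2)ccc1[C@@H](c1ccccc1)[C@@](O)(CCN(C)C)c1cccc2ccccc12`, differs from compound 2 by 3-chlorophenyl in place of 4-cyanophenyl on an aromatic carbon. Going by the values given here, no measured step bears readably on this change: the step from compound 1 to compound 2 exchanged a ring substituent on an aromatic carbon of the same core and sat at the limit at both ends, so no size can be drawn from it. In this assay no step beyond the scatter is therefore expected, and compound 4 is expected to remain at the limit. Compound 4 is estimated at 60 ug/mL with a range of 25 ug/mL to 150 ug/mL. The expected step is a step that the limit leaves unreadable from compound 2 to compound 4.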

Compound 4, half-maximal cytotoxic concentration: > 50 ug/mL
Compound 4 was reported as a limit (the forecaster's own chance of this, stated with the estimate: 85%); the middle value lies beyond the limit too.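

For the compounds shown here, compound 1, compound 2 and compound 4 all stand at a limit of the assay in this assay, so no step among them can be read: the limit of > 50 ug/mL in this assay, at which 4 of the 4 values shown sit. The compounds shown leave open where their true values lie, and whether any group at this place gives a readable value.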